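Shorter Sulfur-Linked Group in Place of Pentyloxy

The compounds below may be only part of what the source reports. "The series", "measured", "known", "first", "only" and "open" are said of these compounds alone.

Of the compounds shown here, three built on one shared core have been measured in a functional assay on the whole organism for activation, with Mus musculus as the target; a higher number here means that more compound is needed for the effect, a lower number that less compound is needed. Compound 1 `Nc1ncnc2c1nc(O)n2Cc1ccc(Cl)cc1` gives 30 mg/kg. Compound 2 `CCCCCNc1nc(N)c2nc(O)n(Cc3ccccc3)c2n1`, which carries a pentylamino group on the core, gives 0.3 mg/kg. Compound 3 `CCCCCOc1nc(N)c2nc(O)n(Cc3ccccc3)c2n1`, which carries a pentyloxy group at that same carbon, gives 0.3 mg/kg. Compound 3 thus stands level with compound 2 at the digits shown, and the two together sit at the lowest number of the three, while compound 1, which differs from them in more than one place, needs a far larger dose, a gap well beyond the scatter.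

The next compound, compound 4 `CSc1nc(N)c2nc(O)n(Cc3ccccc3)c2n1`, is reached by one change: methylsulfanyl in place of pentyloxy on an aromatic carbon. Among the measured compounds shown here, only one measured step bears on it. The step of no change at the digits printed from compound 2 to compound 3 (within the scatter) shows that exchanging the atom that links the five-carbon chain to the core leaves the dose unchanged, so the swap of oxygen for sulfur alone is not expected to matter. For the measured compounds named here, no measured step shows what shortening the chain from pentyl to methyl does, and compound 1 cannot settle it. A modest rise in dose is therefore expected as the step of a 3.3-fold higher number from compound 3 to compound 4 (0.52 log units; beyond the scatter). Compound 4 is estimated at 1 mg/kg, within a range from 0.3 mg/kg to 10 mg/kg.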

Compound 4, minimum effective dose: 0.1 mg/kg
Compound 4: the middle estimate sits 10-fold (1.00 log units) above what was measured; the whole stated range lies above it.
By their numbers in this assay, from the lowest: compound 4; then compounds 2 and 3 (each within the scatter of the next); then compound 1.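

Among the compounds shown here, at this aromatic carbon, between two ring nitrogen atoms, the earlier compounds showed only that a pentylamino group and a pentyloxy group could not be told apart in this assay, whereas the methylsulfanyl group now gives a 3.0-fold lower number from compound 3 to compound 4 (0.48 log units; beyond the scatter) and, measured against the pentylamino group, a 3.0-fold lower number from compound 2 to compound 4 (0.48 log units; beyond the scatter) in the same test. A long chain is therefore not required here for a low dose, since a group of 2 heavy atoms does better than one of 6 at this position. Nothing available explains why the smaller sulfur-linked group needs less compound.

From the compounds shown here alone, compound 4 changes the linking atom and the chain length at once, so how much of the step belongs to the sulfur and how much to the shorter chain remains open, and a methoxy group or a pentylsulfanyl group at this carbon would separate the two. Also open, going by these compounds, is how the dose responds across the chain lengths between methyl and pentyl, as with an ethylsulfanyl or a butylsulfanyl group, and whether a methylamino group would follow the methylsulfanyl group.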